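The compounds below may be only part of what the source reports. "The series", "measured", "known", "first", "only" and "open" are said of these compounds alone.

Compound 2, `CN1C(=S)[C@@H](NC(=O)c2nc(Cc3ccccc3)n(CCCC(F)(F)F)n2)COc2ccccc21`, is the starting point here. In a toxicity assay on HT-29 cells (Homo sapiens) for cytotoxicity (a higher number here means that more compound is tolerated, a lower number that less compound is tolerated), compound 2 gives > 100000 nM, which is a limit of the assay rather than a number. Within the data shown here, its only measured relative is compound 1, `CC(C)CCn1nc(C(=O)N[C@H]2COc3ccccc3N(C)C2=S)nc1Cc1ccccc1`. In this assay compound 1 gives > 100000 nM, again a limit. The step that the two limits leave unreadable from compound 1 to compound 2 therefore cannot be read, since (the limit of > 100000 nM in this assay, at which 2 of the 2 values shown sit).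

The new compound is compound 3, `CN1C(=S)[C@@H](NC(=O)c2nc(Cc3ccccc3)n(C3CCCCCC3)n2)COc2ccccc21`. The change from compound 2 is cycloheptyl in place of 4,4,4-trifluorobutyl on an aromatic nitrogen, a cycloheptyl in place of 4,4,4-trifluorobutyl on an aromatic nitrogen. Among the measured compounds shown here, no measured step shows how such a change moves this assay, and both measured values sit at the same limit, so no direction can be drawn from them.

The expectation for compound 3 is therefore that it too is tolerated up to the limit, an estimated 100000 nM with a range of 30000 nM to 300000 nM, which is an expected step of a number no higher from compound 2 to compound 3 (the limit leaves the size open).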

Compound 3, half-maximal cytotoxic concentration: > 100000 nM
Compound 3 gave a limit, no number; the forecaster's own chance of this, stated with the estimate: 75%; the middle value sits exactly at the limit.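

Compound 1, compound 2 and compound 3 all end at the same limit of the assay, so none of the steps between them can be read: the limit of > 100000 nM in this assay, at which 3 of the 3 values shown sit.

The compounds shown leave open whether isopentyl, 4,4,4-trifluorobutyl and cycloheptyl on the aromatic nitrogen differ at all in this assay.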